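The source may report more compounds than this note shows. Statements on the series, on what has been measured and on what is new or still open speak of the compounds shown alone.

Working notes on the series. Of the compounds shown here, two carry numbers so far. Compound 1 `Nc1ncc(-c2cnn(C3CCNCC3)c2)cc1-c1nc2cc(Nc3ccccc3)ccc2o1` and compound 2 `Nc1ncc(-c2cnn(C3CCNCC3)c2)cc1-c1nc2ccc(Nc3ccc(F)cc3)cc2o1` share one core and differ in a single region of the structure. In an assay on isolated protein for inhibition of G protein-coupled receptor kinase 5 (Homo sapiens), read by TR-FRET, with stated times of 10 min and 1 h (a higher number here means a weaker inhibitor, a lower number a stronger inhibitor), compound 1 gives 3500 nM, and in this assay compound 2 gives 3700 nM. Compound 2 holds the highest of the two numbers, yet its nearest neighbour is compound 1, and the gap between them falls within the usual scatter of repeated measurements, so no order can be read from the pair. For the measured compounds named here, nothing measured so far tells how a change of the kind described below moves the number.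

Compound 3 `Nc1ncc(-c2cnn(C3CCNCC3)c2)cc1-c1nc2ccc(NC(=O)c3ccccc3)cc2o1` has not yet been measured in this assay. It differs from compound 2 in one place: benzoyl in place of 4-fluorophenyl on a nitrogen on an aromatic ring. Going by the values given here, no measured pair shows the effect of such a swap, so the size of the step cannot be read from the data. The expectation is of a step close to the scatter, in no firm direction, so the step of a 1.1-fold higher number from compound 2 to compound 3 (0.03 log units; within the scatter) is expected to be small. Compound 3 is estimated at 4000 nM in this assay, with a range from 1200 nM to 13000 nM.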

Compound 3, half-maximal inhibitory concentration: 3490 nM
For compound 3 the middle estimate is 1.1-fold (0.06 log units) above the measured one; the measured number falls inside the stated range.
By their numbers in this assay, from the lowest: compounds 3, 1 and 2 (each within the scatter of the next).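

In this assay, for the compounds shown here, benzoyl in place of 4-fluorophenyl on a nitrogen on an aromatic ring gives a 1.1-fold lower number from compound 2 to compound 3 (0.03 log units; within the scatter), the first step between measured compounds that differ in one place. At this position, the numbers do not separate the (4-fluorophenyl)amino form from the benzamido form, even though the entering benzoyl brings a double bond outside aromatic rings and a hydrogen-bond acceptor that the leaving 4-fluorophenyl lacks. No measured finding is available that could account for this lack of separation.

Both groups compared on this nitrogen carry one six-membered aromatic ring of carbon only, so the series does not yet show what an acetyl group, a longer alkyl chain, or a benzoyl bearing an amine or a carboxylic acid would do to the number. Also open, on these data alone, is whether the amide hydrogen of compound 3 matters, which a methyl group on that nitrogen would test.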